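The source may hold more compounds than are shown below. What is called first, only, known or untested is meant among the compounds shown, and "the series" means these compounds.

- compound 1 `CN(C)CCNc1nc2c(c(=N)n1-c1ccccc1)c(=S)n(-c1ccccc1)c(=S)n2-c1ccccc1`: 8400 nM
- compound 2 `CCN(CC)CCNc1nc2c(c(=N)n1-c1ccccc1)c(=S)n(-c1ccccc1)c(=S)n2-c1ccccc1`: 2500 nM
- compound 3 `N=c1c2c(=S)n(-c3ccccc3)c(=S)n(-c3ccccc3)c2nc(NCc2ccccn2)n1-c1ccccc1`: 7000 nM

All three were tested in a functional assay on MT4 cells (Homo sapiens) for cytotoxicity; on this read-out higher numbers stand for weaker inhibition and lower numbers for stronger inhibition. Compound 3 stands at the higher end of this small set, level with compound 1 and above compound 2: a 1.2-fold lower number from compound 1 to compound 3 (0.08 log units; within the scatter), and a 2.8-fold higher number from compound 2 to compound 3 (0.45 log units; beyond the scatter).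

Compound 4 `N=c1c2c(=S)n(-c3ccccc3)c(=S)n(-c3ccccc3)c2nc(NCCCn2ccnc2)n1-c1ccccc1` changes one group of compound 3: 2-(1H-imidazol-1-yl)ethyl in place of pyridin-2-yl on a saturated chain carbon bound to a nitrogen on an aromatic ring. It carries 2-(1H-imidazol-1-yl)ethyl in place of pyridin-2-yl on a saturated chain carbon bound to a nitrogen on an aromatic ring. The two steps above altered the group at this same place, and both were small, so no step beyond the scatter is expected here. The expected change is a 1.2-fold lower number from compound 3 to compound 4 (0.07 log units; within the scatter). Compound 4 is estimated at 6000 nM, with an expected range of 2500 nM to 14000 nM.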

Compound 4, half-maximal inhibitory concentration: 8000 nM
Compound 4: middle estimate off by 1.3-fold (0.12 log units), on the low side; low and high end bracket the measured number.
By their numbers in this assay, from the lowest: compound 2; then compounds 3, 4 and 1 (each within the scatter of the next).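

In this assay, 2-(1H-imidazol-1-yl)ethyl in place of pyridin-2-yl leaves the number unchanged within the scatter (a 1.1-fold higher number from compound 3 to compound 4 (0.06 log units; within the scatter)), and the comparison with the dimethylamino group is just as flat (a 1.1-fold lower number from compound 1 to compound 4 (0.02 log units; within the scatter)). Only the diethylamino group of compound 2 stands apart (a 3.2-fold higher number from compound 2 to compound 4 (0.51 log units; beyond the scatter)), so a five-membered aromatic ring with 2 hetero atoms does not separate itself from the other two groups. Nothing measured here explains this.

As far as these compounds go, what a morpholin-4-yl group or a carboxylic acid would do at this place stays open. So does the effect of a longer chain carrying the same imidazole.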